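Stripping the bromoethenyl carbonyl from compound 2

The source may report more compounds than this note shows. Statements on the series, on what has been measured and on what is new or still open speak of the compounds shown alone.

Measured in an ADME assay on CCRF-CEM cells (Homo sapiens) for antiproliferative activity, with a stated time of 48 h; on this read-out higher numbers stand for weaker inhibition and lower numbers for stronger inhibition:
- compound 1 `C=C(Br)C(=O)Nc1ccc(C(=O)/C=C/c2ccc(OC)cc2)cc1`: 1100 nM
- compound 2 `C=C(Br)C(=O)Nc1ccc(C(=O)/C=C/c2ccc(OC)cc2OC)cc1`: 1100 nM

Compound 2 stands level with compound 1 in this assay. Among the compounds with values here, the only measured step, no change at the digits printed from compound 1 to compound 2 (within the scatter), is methoxy in place of hydrogen on an aromatic carbon, and it stays within the scatter. It does not cover the change at hand. Compound 3 `COc1ccc(/C=C/C(=O)c2ccc(N)cc2)c(OC)c1` differs from compound 2 by hydrogen in place of (1-bromoethenyl)carbonyl on a nitrogen on an aromatic ring. This takes away a group that both measured compounds carry, so a clear step towards weaker inhibition is expected, though no measurement fixes its size. The estimated step is an 11-fold higher number from compound 2 to compound 3 (1.04 log units; beyond the scatter). Compound 3 is expected at 12000 nM, with an estimated range from 3000 nM to 45000 nM.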

Compound 3, half-maximal inhibitory concentration: 18000 nM
Beside the measured number, compound 3's estimate is 1.5-fold (0.18 log units) below it; low and high end bracket the measured number.
By their numbers in this assay, from the lowest: compounds 1 and 2 (each within the scatter of the next); then compound 3.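

In this assay, the change on the nitrogen gives a 16-fold higher number from compound 2 to compound 3 (1.21 log units; beyond the scatter), so this position responds strongly, whereas the methoxy change between compounds 1 and 2 stayed within the scatter. Compound 3, with its plain amino group, still gives a measurable 18000 nM, so the inhibition does not vanish without (1-bromoethenyl)carbonyl. No available evidence accounts for the size of this step.

The compounds shown leave open which part of the lost group matters: the bromine, the double bond or the carbonyl. An acetyl or a propenoyl group on that nitrogen would begin to separate them.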